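Swapping phenyl for sec-butyl on a hydantoin-type core

The compounds below may be only part of what the source reports. "The series", "measured", "known", "first", "only" and "open" are said of these compounds alone.

Compound 1, `CCC(C)C(NC(=O)n1nnc2ccccc21)C(=O)NCc1ccccc1`, in a functional assay on MIA PaCa-2 cells (Homo sapiens) for inhibition (a lower number here means a stronger inhibitor, a higher number a weaker inhibitor), gives > 100000 nM, a limit of the assay rather than a number.
Compound 2, `CCC(C)C(NC(=O)n1nnc2ccccc21)C(=O)NC1CCCC1`, gives >= 100000 nM, again a limit of the assay.
Compound 3, `O=C1NC(c2ccccc2)C(=O)N1C1CCCC1`, gives > 100000 nM, also a limit of the assay.

Compound 3 therefore stands only at a limit, and the same holds for the two other measured compounds, as the limit of > 100000 nM in this assay, at which 2 of the 3 values shown sit, and the limit of >= 100000 nM in this assay, at which 1 of the 3 values shown sits, show. Among the compounds with values here, the only measured step, a step that the two limits leave unreadable from compound 1 to compound 2, runs between two limits and its size cannot be read.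

Compound 4, `CCC(C)C1NC(=O)N(C2CCCC2)C1=O`, differs from compound 3 by sec-butyl in place of phenyl on a saturated ring carbon. Within the data shown here, no measured step in this set bears on a change of that kind, and the one step that exists gives no size at all. Since every measured value sits at a limit, there is no ground to expect compound 4 to move beyond the scatter in either direction, and a further limit is the most probable outcome.

Compound 4 is accordingly estimated at 150000 nM, with a range from 30000 nM to 1000000 nM, which means an expected step that the limit leaves unreadable from compound 3 to compound 4.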

Compound 4, half-maximal inhibitory concentration: > 100000 nM
Compound 4 gave a limit, no number; the forecaster's own chance of this, stated with the estimate: 85%; the middle value does not contradict the limit.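

Compound 3 and compound 4 both stand at a limit of the assay rather than at a number, so the step from phenyl to sec-butyl cannot be read. The compounds shown leave open which change to these structures, if any, would give a measurable value in this assay.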